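A few compounds are considered here, and "the series" means these few. Any claim that something is new, unique, unknown or untested is made for them only; others in the source may bear on it.

The measured compounds:
Compound 1 `O=C(O)CC1CCN(c2ccc(OCc3ccc(Cl)cc3Cl)cc2)C1` gives > 33000 nM in a functional assay on cells for agonist activity at Free fatty acid receptor 1 (Mus musculus), read by FLIPR and calcium flux, with a stated time of 100 s (a lower number here means that less compound is needed, a higher number that more compound is needed for the effect), a limit of the assay and not a number.
Compound 2 `Cc1ccccc1Oc1ccc(N2C[C@@H](C(F)(F)F)C[C@H]2CC(=O)O)cc1` gives 330 nM in this assay.
Compound 3 `Cc1ccccc1Oc1ccc(N2CCC[C@H]2CC(=O)O)cc1` gives 5600 nM in this assay.

Of the two numbers in this assay, compound 3 carries the higher one. Its nearest neighbour is compound 2, and the two are separated by a 17-fold higher number from compound 2 to compound 3 (1.23 log units; beyond the scatter), a step that lies beyond the scatter. The value of compound 1 is a limit only (the limit of > 33000 nM in this assay, at which 1 of the 3 values shown sits).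

Compound 4 `Cc1cccc(Oc2ccc(N3CCC[C@H]3CC(=O)O)cc2)c1` differs from compound 3 by 3-methylphenyl in place of 2-methylphenyl on an oxygen on an aromatic ring. Going by the values given here, the single measured step, a 17-fold higher number from compound 2 to compound 3 (1.23 log units; beyond the scatter), concerns a hydrogen in place of a trifluoromethyl on a saturated ring carbon; it leaves the methylphenyl group untouched, so no measured step bears on the change from compound 3 to compound 4. With nothing in the data to set a direction, the step in this assay is expected to be small, and more likely within the scatter than beyond it. Compound 4 is therefore estimated at 7000 nM, with a range from 2500 nM to 20000 nM. The step this estimate implies is expected to be a 1.3-fold higher number from compound 3 to compound 4 (0.10 log units; within the scatter).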

Compound 4, half-maximal effective concentration: 2400 nM
Compound 4: the middle estimate sits 2.9-fold (0.46 log units) above what was measured, outside the stated range (below it).
By their numbers in this assay, from the lowest: compound 2; then compound 4; then compound 3. At a limit, above all of these: compound 1.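

In this assay, 3-methylphenyl in place of 2-methylphenyl on an oxygen on an aromatic ring gives a 2.3-fold lower number from compound 3 to compound 4 (0.37 log units; beyond the scatter), so the number responds at this position even though the two compounds have the same atoms, joined differently. Going by these compounds alone, the earlier measured step concerned a different place, hydrogen in place of trifluoromethyl on a saturated ring carbon, and this new step is the first to show that the methylphenyl group also affects the number, modestly where the earlier step was large. Nothing measured here accounts for the difference between the two methylphenyl groups.

From the compounds shown here alone, what an unsubstituted phenyl, a chlorophenyl or a methoxyphenyl would give on the same oxygen remains open, so a single pair cannot show whether the methyl group itself contributes or how far the trend extends. It also remains open whether 3-methylphenyl and trifluoromethyl on the saturated ring carbon would combine in this assay, since the compounds shown do not carry that pairing.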